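Piperidin-1-yl to dimethylamino on the side chain

This account rests on a few compounds, and the source may have more. Where it says the series, first, only, none or still open, it means among the compounds named here.

In a functional assay on HCT-116 cells (Homo sapiens) for antiproliferative activity, read by sulforhodamine B assay, with a stated time of 72 h (on this read-out higher numbers stand for weaker inhibition and lower numbers for stronger inhibition), compound 1 `Cn1ncc(Cl)c1-c1cc(C(=O)N[C@@H]2CN[C@H](CCn3cncn3)C[C@H]2c2ccc(Cl)c(Cl)c2)oc1Cl` gives 560 nM as its reading and compound 2 `Cn1ncc(Cl)c1-c1cc(C(=O)N[C@@H]2CN[C@H](CCN3CCCCC3)C[C@H]2c2ccc(Cl)c(Cl)c2)oc1Cl` gives 1020 nM as its reading. Among the measured compounds shown here, compound 2 thus stands within the scatter of compound 1, its only measured neighbour. The next change leads to compound 3 `CN(C)CC[C@@H]1C[C@@H](c2ccc(Cl)c(Cl)c2)[C@H](NC(=O)c2cc(-c3c(Cl)cnn3C)c(Cl)o2)CN1` and is counted as dimethylamino in place of piperidin-1-yl on a saturated chain carbon, two bonds along the chain from a saturated ring carbon with dimethylamino in place of piperidin-1-yl on a saturated chain carbon, two bonds along the chain from a saturated ring carbon. For the measured compounds named here, one measured step bears on it, at the same carbon, with piperidin-1-yl in place of 1H-1,2,4-triazol-1-yl: a 1.8-fold higher number from compound 1 to compound 2 (0.26 log units; within the scatter) for that swap. No step beyond the scatter is therefore expected in this assay and the expected move is a 1.3-fold lower number from compound 2 to compound 3 (0.11 log units; within the scatter) as the working figure. In this assay the estimated value for compound 3 is 800 nM with 350 nM to 1800 nM as the expected range.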

Compound 3, half-maximal inhibitory concentration: 1710 nM
For compound 3 the middle estimate is 2.1-fold (0.33 log units) below the measured one; the measured number falls inside the stated range.
By their numbers in this assay, from the lowest: compounds 1, 2 and 3 (each within the scatter of the next, the first and the last beyond it).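

In this assay the exchange of the ring amine for the open-chain amine gives a 1.7-fold higher number from compound 2 to compound 3 (0.22 log units; within the scatter) and so does not separate piperidin-1-yl from dimethylamino at this position, on a saturated chain carbon, two bonds along the chain from a saturated ring carbon. Among the compounds shown here, the comparison of dimethylamino with 1H-1,2,4-triazol-1-yl at the same place gives a 3.1-fold higher number from compound 1 to compound 3 (0.48 log units; beyond the scatter) and is the only step here beyond the scatter, with piperidin-1-yl within the scatter of both. No measurement to hand accounts for this modest separation.

Open, as far as these compounds go, is whether an imidazol-1-yl group, a morpholin-4-yl group or a carboxylic acid at this place would read with 1H-1,2,4-triazol-1-yl or with the two amines. Also open, from the compounds shown here alone, is whether a longer chain carrying dimethylamino or 1H-1,2,4-triazol-1-yl would keep the same separation.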